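Pyridin-4-yl to 4-bromophenyl on the shared core

The source may report more compounds than this note shows. Statements on the series, on what has been measured and on what is new or still open speak of the compounds shown alone.

- compound 1 `CCOCCOn1c(-c2cccc(C#N)c2)nc(C)c1C(=O)OCC`: 6250 nM
- compound 2 `CCOC(=O)c1c(C)nc(-c2cccc(C#N)c2)n1OCCC(=O)O`: > 30000 nM
- compound 3 `CCOC(=O)c1c(C)nc(-c2cccc(C#N)c2)n1OCc1ccncc1`: 6200 nM

In a functional assay on a cell-free system (plasma, Oryctolagus cuniculus) for inhibition, with stated times of 5 min, 1 min and 6 min (a lower number here means a stronger inhibitor, a higher number a weaker inhibitor), compound 3 gives 6200 nM, within the scatter of compound 1. Compound 2 reports only a limit, > 30000 nM. Compound 4 `CCOC(=O)c1c(C)nc(-c2cccc(C#N)c2)n1OCc1ccc(Br)cc1` carries 4-bromophenyl in place of pyridin-4-yl on a saturated chain carbon bound to an oxygen on an aromatic ring.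

Among the measured compounds shown here, no measured step swaps one ring for another. The nearest guide is a 1.0-fold lower number from compound 1 to compound 3 (0.00 log units; within the scatter), a change at this same carbon. The clear shifts, an at least 4.8-fold higher number from compound 1 to compound 2 (0.68 log units; beyond the scatter) and an at least 4.8-fold lower number from compound 2 to compound 3 (0.68 log units; beyond the scatter), both involve the carboxy group, which compound 4 lacks. The expected change is therefore small, a 1.2-fold lower number from compound 3 to compound 4 (0.09 log units; within the scatter), with no step beyond the scatter anticipated. For compound 4 the estimated value is 5000 nM, with an expected range of 1500 nM to 20000 nM.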

Compound 4, half-maximal inhibitory concentration: 24600 nM
Beside the measured number, compound 4's estimate is 4.9-fold (0.69 log units) below it; measured number outside the range, above it.
By their numbers in this assay, from the lowest: compounds 3 and 1 (each within the scatter of the next); then compound 4. At a limit, above all of these: compound 2.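

In this assay, 4-bromophenyl in place of pyridin-4-yl on a saturated chain carbon bound to an oxygen on an aromatic ring gives a modest step: a 4.0-fold higher number from compound 3 to compound 4 (0.60 log units; beyond the scatter). Compound 4 also separates from the ethoxymethyl compound, a 3.9-fold higher number from compound 1 to compound 4 (0.60 log units; beyond the scatter), so a clear shift occurs here without a carboxy group, whereas compounds 1 and 3 sit within the scatter of each other. Compound 2 stands at a limit: the limit of > 30000 nM in this assay, at which 1 of the 4 values shown sits. Its step to compound 4 gives only a floor: an at least 1.2-fold lower number from compound 2 to compound 4 (0.08 log units; that floor lies within the scatter).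

The compounds shown do not tell whether losing the ring nitrogen or gaining the bromine drives the shift. A plain phenyl ring at this place would separate the two.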